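The source may hold more compounds than are shown below. What is called first, only, known or untested is meant among the compounds shown, and "the series" means these compounds.

Measured compounds in an ADME assay on Vero cells (Chlorocebus sabaeus) for cytotoxicity, read by resazurin assay, with a stated time of 3 days; a higher number here means a weaker inhibitor, a lower number a stronger inhibitor:
Compound 1 `CCN(CC)c1cc2[nH]c(C3CCCCC3)nc2cc1NC(=O)c1ccc(OC(F)(F)F)cc1` gives > 100 ug/mL, a limit of the assay.
Compound 2 `CN(C)c1cc2[nH]c(C3CCCCC3)nc2cc1NC(=O)c1ccccc1` gives > 100 ug/mL, a limit of the assay.
Compound 3 `CN(C)c1cc2[nH]c(C3CCCCC3)nc2cc1NC(=O)c1ccc(F)cc1` gives > 100 ug/mL, a limit of the assay.

Compound 3 therefore stands at the limit in this assay, with no number known for it. The step that the two limits leave unreadable from compound 2 to compound 3 is of unreadable size. The change to compound 4 `CN(C)c1cc2[nH]c(C3CCCCC3)nc2cc1NC(=O)c1ccc(OC(F)(F)F)cc1` is trifluoromethoxy in place of fluoro on an aromatic carbon. Among the compounds with values here, no measured step bears directly on it; compound 1 carries the same trifluoromethoxy group on a core that differs elsewhere from that of compound 3, and its value and that of compound 3 show only that each sits at the limit. Since (the limit of > 100 ug/mL in this assay, at which 3 of the 3 values shown sit), no step beyond the scatter is expected in this assay. Compound 4 is expected to remain at or near the limit, estimated at 150 ug/mL (range 60 ug/mL to 400 ug/mL). The step that the limit leaves unreadable from compound 3 to compound 4 is expected to be none beyond the scatter.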

Compound 4, half-maximal inhibitory concentration: > 100 ug/mL
Compound 4 gave a limit, no number; the forecaster's own chance of this, stated with the estimate: 85%; the middle value lies beyond the limit too.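

The steps to compound 4 from compound 1, compound 2 and compound 3 cannot be read, as all four compounds stand at a limit: the limit of > 100 ug/mL in this assay, at which 4 of the 4 values shown sit.

The compounds shown leave open whether any substituent on the shared core changes the read-out in this assay.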